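The source may report more compounds than this note shows. Statements on the series, on what has been measured and on what is new or still open speak of the compounds shown alone.

Measured compounds:
compound 1 `CC#C[C@@H](Cc1nnn[nH]1)c1ccc(OCc2ccc3sc(F)c(-c4ccccc4C)c3c2)cc1`, 14 nM
compound 2 `CC#C[C@@H](Cc1nnn[nH]1)c1ccc(OCc2ccc3scc(-c4cc(OCCOC)ccc4C)c3c2)cc1`, 26 nM
compound 3 `CC#C[C@@H](Cc1nnn[nH]1)c1ccc(OCc2cc(Cl)c3scc(-c4ccccc4C)c3c2)cc1`, 108 nM

In a functional assay on cells for agonist activity at Free fatty acid receptor 1 (Rattus norvegicus), read by FLIPR and calcium flux (a lower number here means that less compound is needed, a higher number that more compound is needed for the effect), compound 2 gives 26 nM, the second highest of the three numbers. Compound 1 lies nearest, and the gap between the two is within the scatter of repeat measurements; compound 3 lies furthest, its higher number beyond that scatter. Compound 4 `CC#C[C@@H](Cc1nnn[nH]1)c1ccc(OCc2ccc3scc(-c4ccc(OCCOC)cc4C)c3c2)cc1` has not been measured. It differs from compound 2 in one place: 4-(2-methoxyethoxy)-2-methylphenyl in place of 5-(2-methoxyethoxy)-2-methylphenyl on an aromatic carbon. Among the compounds with values here, none of the measured compounds shows what this change does, so no step beyond the scatter is expected in this assay in either direction. Compound 4 is therefore estimated to give 30 nM, with a range from 10 nM to 90 nM. The expected step is a 1.2-fold higher number from compound 2 to compound 4 (0.06 log units; within the scatter).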

Compound 4, half-maximal effective concentration: 4 nM
Estimate against measurement, compound 4: 7.5-fold (0.88 log units) above; the whole stated range lies above it.
By their numbers in this assay, from the lowest: compound 4; then compounds 1 and 2 (each within the scatter of the next); then compound 3.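

In this assay, 4-(2-methoxyethoxy)-2-methylphenyl in place of 5-(2-methoxyethoxy)-2-methylphenyl gives a 6.5-fold lower number from compound 2 to compound 4 (0.81 log units; beyond the scatter) with no change in atoms. This shows that, on the aromatic carbon two ring bonds from the ring sulfur, the way this aryl group is joined affects the number, not only which atoms it contains. Nothing measured here explains the step.

The compounds shown leave open whether a longer chain, an amine or a carboxylic acid in place of the 2-methoxyethoxy chain would retain this lower number.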